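Swapping methoxy for fluoro at a cytotoxicity limit

This account rests on a few compounds, and the source may have more. Where it says the series, first, only, none or still open, it means among the compounds named here.

Compound 1 `C=C[C@@](C)(/C=C/c1ccc(OS(=O)(=O)C(F)(F)F)cc1)CCC=C(C)C` gives > 52000 nM (a limit)
Compound 2 `C=C[C@@](C)(/C=C/c1ccc(Nc2ccc(OC)c(F)c2)cc1)CCC=C(C)C` gives > 52000 nM (a limit)
Compound 3 `C=C[C@@](C)(/C=C/c1ccc(Nc2ccc(F)c(F)c2)cc1)CCC=C(C)C` has not yet been measured

Both results come from a functional assay on HepG2 cells (Homo sapiens) for cytotoxicity, with a stated time of 72 h (on this read-out lower numbers stand for an effect already at smaller amounts and higher numbers for an effect only at larger amounts of compound), and neither gives an exact number. In this assay compound 2 gives > 52000 nM as its result, which is a limit of the assay and not a number. Among the compounds with values here, the picture so far is the limit of > 52000 nM in this assay, at which 2 of the 2 values shown sit, and no measured step is available to show how far a structural change can move the read-out.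

Compound 3 keeps the core of compound 2 and changes one group, from 3-fluoro-4-methoxyphenyl to 3,4-difluorophenyl. The change is fluoro in place of methoxy on an aromatic carbon and it places fluoro in place of methoxy on an aromatic carbon, para to a large group.

No shift beyond the usual scatter is expected in this assay in either direction. The expected size is a number no higher from compound 2 to compound 3 (the limit leaves the size open) as an estimate. This expectation rests on compound 2 at > 52000 nM as its limit. For compound 3 the estimate is 52000 nM with an expected range of 25000 nM to 100000 nM as its span.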

Compound 3, half-maximal effective concentration: > 52000 nM
Compound 3: only a limit was reported; the forecaster's own chance of this, stated with the estimate: 75%; the middle value sits exactly at the limit.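

In this assay, compound 1, compound 2 and compound 3 each give only a limit, and the steps from compound 1 and from compound 2 to compound 3 cannot be read. The compounds shown leave open whether fluoro in place of methoxy changes the read-out at all, with every result at one limit: the limit of > 52000 nM in this assay, at which 3 of the 3 values shown sit.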